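Shortening the Nitrooxy Chain of Compound 2

This account rests on a few compounds, and the source may have more. Where it says the series, first, only, none or still open, it means among the compounds named here.

In a functional assay on NCI-H1792 cells (Homo sapiens) for cytotoxicity, read by resazurin assay, with a stated time of 72 h (on this read-out lower numbers stand for stronger inhibition and higher numbers for weaker inhibition), compound 1 `COc1cc(/C=C/C(=O)OCCCCOc2no[n+]([O-])c2S(=O)(=O)c2ccccc2)ccc1O` gives 420 nM. Compound 2 `COc1cc(/C=C/C(=O)OCCCCCCO[N+](=O)[O-])ccc1O` gives 48700 nM, the higher of the two numbers, and its gap to compound 1 lies well beyond the scatter. Compound 3 `COc1cc(/C=C/C(=O)OCCCO[N+](=O)[O-])ccc1OCCCO[N+](=O)[O-]` gives only a limit, > 50000 nM.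

The next compound to be tested, compound 4 `COc1cc(/C=C/C(=O)OCCCCCO[N+](=O)[O-])ccc1O`, departs from compound 2 in one place: nitrooxy in place of (nitrooxy)methyl on a saturated chain carbon, five bonds along the chain from an oxygen next to a carbonyl group. Nitrooxy stands in place of (nitrooxy)methyl on a saturated chain carbon, five bonds along the chain from an oxygen next to a carbonyl group. Going by the values given here, no measured pair isolates this kind of change, so the expectation starts from compound 2 at 48700 nM and assumes that so small a change leaves the number close to where it stands. The expected step is a 1.1-fold lower number from compound 2 to compound 4 (0.03 log units; within the scatter), which stays within the scatter in this assay and has no clear direction. For compound 4 the estimated value is 45000 nM, with an expected range of 20000 nM to 80000 nM.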

Compound 4, half-maximal inhibitory concentration: 13000 nM
The estimate for compound 4 lay 3.5-fold (0.54 log units) above the measured number, and the stated range ends above it.
By their numbers in this assay, from the lowest: compound 1; then compound 4; then compound 2. At a limit, above all of these: compound 3.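

In this assay, this is the first pair among the compounds shown that differs in one place, and it gives a 3.7-fold lower number from compound 2 to compound 4 (0.57 log units; beyond the scatter). The earlier compounds shown here could not show that this position responds to the change, but nitrooxy in place of (nitrooxy)methyl, on a saturated chain carbon five bonds along the chain from an oxygen next to a carbonyl group, moves the number beyond the scatter, though only modestly. Nothing shown here bears on why so small a change has this effect.

A single step sets no trend, so the compounds shown leave open whether a still shorter chain would continue in this direction or reverse it. They also leave open whether the nitrooxy group itself matters at the chain end, as a hydroxyl, an amine or a carboxylic acid there would test.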